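Two Fluorines Enter the Phenyl Ring: What to Expect

This account rests on a few compounds, and the source may have more. Where it says the series, first, only, none or still open, it means among the compounds named here.

Compound 1, `Nc1nc(N)c2cc(CSC(=S)N3CCN(c4ccccc4)CC3)ccc2n1`, gives 2840 nM in a functional assay on HeLa cells (Homo sapiens) for antiproliferative activity, read by MTT assay, with a stated time of 72 h; a lower number here means a stronger inhibitor, a higher number a weaker inhibitor.
Compound 2, `Cc1ccc(N2CCN(C(=S)SCc3ccc4nc(N)nc(N)c4c3)CC2)cc1`, gives 2130 nM.
Compound 3, `Nc1nc(N)c2cc(CSC(=S)N3CCN(c4ccccc4F)CC3)ccc2n1`, gives 6660 nM.

Among these three numbers, compound 1 sits second highest; the step of a 1.3-fold lower number from compound 1 to compound 2 (0.12 log units; within the scatter) stays within the scatter, while a 2.3-fold higher number from compound 1 to compound 3 (0.37 log units; beyond the scatter) goes beyond it. Compound 4, `Nc1nc(N)c2cc(CSC(=S)N3CCN(c4ccc(F)cc4F)CC3)ccc2n1`, has not yet been measured; its change from compound 1 is 2,4-difluorophenyl in place of phenyl on an amine nitrogen in a ring. The nearest guide is the single fluoro that entered in a 2.3-fold higher number from compound 1 to compound 3 (0.37 log units; beyond the scatter), where a modest rise in the number followed, and a 3.1-fold higher number from compound 2 to compound 3 (0.50 log units; beyond the scatter) points the same way. With two fluorines entering, a modest to somewhat larger rise is expected, so compound 4 is estimated at 8000 nM, within a range from 3000 nM to 20000 nM, which would make a 2.8-fold higher number from compound 1 to compound 4 (0.45 log units; beyond the scatter) the expected step.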

Compound 4, half-maximal inhibitory concentration: 3800 nM
The estimate for compound 4 lay 2.1-fold (0.32 log units) above the measured number; the measured number falls inside the stated range.
By their numbers in this assay, from the lowest: compounds 2, 1, 4 and 3 (each within the scatter of the next, the first and the last beyond it).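

In this assay, a second fluoro on the ring of compound 3 does not push the number further up (a 1.8-fold lower number from compound 3 to compound 4 (0.24 log units; within the scatter)). The 2,4-difluorophenyl group instead stands level with phenyl (a 1.3-fold higher number from compound 1 to compound 4 (0.13 log units; within the scatter)) and with 4-methylphenyl (a 1.8-fold higher number from compound 2 to compound 4 (0.25 log units; within the scatter)), so at this position the rise seen with the first fluoro does not build with the second. Nothing measured here accounts for this.

Still open, from the compounds shown here alone, is whether an amine or a carboxylic acid on the phenyl ring, or a longer chain in place of that ring on the amine nitrogen, would move the number beyond the scatter.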